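The compounds below may be only part of what the source reports. "The series", "measured", "known", "first", "only" and "open" are said of these compounds alone.

Three compounds were measured in a functional assay on MCF7 cells (Homo sapiens) for inhibition, read by MTT assay, with a stated time of 72 h; on this read-out higher numbers stand for weaker inhibition and lower numbers for stronger inhibition:

compound 1 `Cc1ccc(NC(=O)c2ccc(/N=N\c3c[nH]c4ccccc34)cc2)cc1`: 42400 nM
compound 2 `O=C(Nc1ccc([N+](=O)[O-])cc1)c1ccc(/N=N\c2c[nH]c3ccccc23)cc1`: 54500 nM
compound 3 `Cc1cccc(NC(=O)c2ccc(/N=N\c3c[nH]c4ccccc34)cc2)c1`: 73400 nM

Compound 2 differs from compound 1 by nitro in place of methyl on an aromatic carbon, and the step was a 1.3-fold higher number from compound 1 to compound 2 (0.11 log units; within the scatter). Compound 3 differs from compound 1 by 3-methylphenyl in place of 4-methylphenyl on an amide-type nitrogen, a step of a 1.7-fold higher number from compound 1 to compound 3 (0.24 log units; within the scatter). Compound 4 `O=C(Nc1cccc([N+](=O)[O-])c1)c1ccc(/N=N\c2c[nH]c3ccccc23)cc1` has not been measured; it differs from compound 3 by nitro in place of methyl on an aromatic carbon. This is the same kind of change as that from compound 1 to compound 2, but the place is not identical: there the nitro sits para to a large group, here meta to a large group. Compound 4 is therefore expected to sit close to compound 3 in this assay, with an estimated step of a 1.0-fold higher number from compound 3 to compound 4 (0.01 log units; within the scatter), resting on the small step of a 1.3-fold higher number from compound 1 to compound 2 (0.11 log units; within the scatter). Compound 4 is estimated at 75000 nM, between 32000 nM and 170000 nM.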

Compound 4, half-maximal inhibitory concentration: 51900 nM
Compound 4: middle estimate off by 1.4-fold (0.16 log units), on the high side, and the stated range covers the measured number.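

In this assay, nitro in place of methyl on the second core gave a 1.4-fold lower number from compound 3 to compound 4 (0.15 log units; within the scatter), and no difference between the two cores can be seen for this change: the same change on two cores in this assay, a 1.3-fold higher number (0.11 log units; within the scatter) from compound 1 to compound 2 and a 1.4-fold lower number (0.15 log units; within the scatter) from compound 3 to compound 4, 1.8-fold (0.26 log units) apart, within the scatter of two such steps. The other two new steps, a 1.1-fold lower number from compound 2 to compound 4 (0.02 log units; within the scatter) and a 1.2-fold higher number from compound 1 to compound 4 (0.09 log units; within the scatter), also lie within the scatter, leaving the 3-nitrophenyl compound 4 indistinguishable from compound 1 and compound 2 on this read-out. This shows that the change carried across these two cores without a detectable shift; it does not show that the change has no effect at all, or that it would behave alike on any other core.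

The compounds shown leave open whether an amine or a carboxylic acid on the phenyl ring in place of methyl or nitro would move the number beyond the scatter.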